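The source may hold more compounds than are shown below. What is called first, only, known or untested is meant among the compounds shown, and "the series" means these compounds.

Compound 1 `Cc1oc(-c2ccc(Cl)c(Cl)c2)nc1CN1CCC(C(=O)NCCCN2C[C@H](C)C[C@H](C)C2)CC1` is the reference point for this step. In an ADME assay on microsomes from liver (Rattus norvegicus) for metabolic stability, read by LC-MS, using NADPH, at 37 degrees C (on this read-out lower numbers stand for a shorter-lived compound and higher numbers for a longer-lived compound), compound 1 gives > 0.5 h, which is a limit of the assay and not a number (the limit of > 0.5 h in this assay, at which 1 of the 2 values shown sits). For the measured compounds named here, compound 2 `Cc1ccccc1-c1nc(CN2CCC(C(=O)NCCCN3CCCC(C(C)C)C3)CC2)c(C)o1` is the only member with a plain number: in this assay compound 2 gives 0.323 h. Compound 3 `COc1cccc(Cl)c1-c1nc(CN2CCC(C(=O)NCCCN3C[C@H](C)C[C@H](C)C3)CC2)c(C)o1` differs from compound 1 by 2-chloro-6-methoxyphenyl in place of 3,4-dichlorophenyl on an aromatic carbon. Going by the values given here, no measured pair covers this change, so in this assay only a small downward step, within the usual scatter, is expected, the step of an at least 1.1-fold lower number from compound 1 to compound 3 (0.04 log units; that floor lies within the scatter). Compound 3 is therefore estimated at 0.45 h, with a range from 0.2 h to 0.9 h.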

Compound 3, half-life: 0.055 h
For compound 3 the middle estimate is 8.2-fold (0.91 log units) above the measured one; the whole stated range lies above it.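

Working notes: the aryl group on the aromatic carbon of the five-membered ring is not a silent position for half-life. In this assay, 2-chloro-6-methoxyphenyl in place of 3,4-dichlorophenyl gives an at least 9.0-fold lower number from compound 1 to compound 3 (0.95 log units; beyond the scatter), a step beyond the usual scatter. That step is only a lower bound because compound 1 has no plain number: the limit of > 0.5 h in this assay, at which 1 of the 3 values shown sits.

Going by these compounds, how the step divides between the methoxy group and the changed chlorine pattern remains open. So does what a plain phenyl or a 2-methoxyphenyl would give at this carbon.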